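Working notes: step from compound 3 to compound 4

A few compounds are considered here, and "the series" means these few. Any claim that something is new, unique, unknown or untested is made for them only; others in the source may bear on it.

Measured so far in a functional assay on Ehrlich cells (Mus musculus) for cytotoxicity, read by trypan blue exclusion, with a stated time of 48 h; on this read-out higher numbers stand for weaker inhibition and lower numbers for stronger inhibition:
compound 1 `Cc1ccc(OCC(=O)NNC(=O)c2cc3ccccc3oc2=O)c(C(=O)c2cccc(Cl)c2)c1` — 67300 nM
compound 2 `Cc1ccc(OCC(=O)NNC(=O)c2cc3ccccc3oc2=O)c(C(=O)c2ccccc2)c1` — 86500 nM
compound 3 `Cc1ccc(OCC(=O)NNC(=O)c2cc3ccccc3oc2=O)c(C(=O)c2cccc(Br)c2)c1` — 68500 nM

Compound 3 gives the second highest of the three numbers; compound 1 lies nearest to it and compound 2 furthest, both within the scatter. Compound 4 `Cc1ccc(OCC(=O)NNC(=O)c2cc3ccccc3oc2=O)c(C(=O)c2ccc(F)cc2)c1` differs from compound 3 by 4-fluorophenyl in place of 3-bromophenyl on a carbonyl carbon. Within the data shown here, the steps that bear on this are a 1.3-fold higher number from compound 1 to compound 2 (0.11 log units; within the scatter), a 1.3-fold lower number from compound 2 to compound 3 (0.10 log units; within the scatter) and a 1.0-fold higher number from compound 1 to compound 3 (0.01 log units; within the scatter); none of them moved the number beyond the scatter, so changes on this ring have so far left the read-out flat. Among the measured compounds shown here, no step in the set shifts where the substituent sits on that ring. Compound 4 is therefore expected to show a 1.1-fold higher number from compound 3 to compound 4 (0.04 log units; within the scatter), nothing beyond the scatter. The estimate for compound 4 is 75000 nM, expected between 40000 nM and 140000 nM.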

Compound 4, half-maximal inhibitory concentration: 43400 nM
Beside the measured number, compound 4's estimate is 1.7-fold (0.24 log units) above it; the measured number falls inside the stated range.
By their numbers in this assay, from the lowest: compounds 4, 1, 3 and 2 (each within the scatter of the next).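

On the carbonyl carbon in this assay, 4-fluorophenyl gives a 1.6-fold lower number from compound 3 to compound 4 (0.20 log units; within the scatter) against 3-bromophenyl and a 1.6-fold lower number from compound 1 to compound 4 (0.19 log units; within the scatter) against 3-chlorophenyl, while it gives a 2.0-fold lower number from compound 2 to compound 4 (0.30 log units; within the scatter) against the unsubstituted phenyl. The flat read-out therefore extends to 4-fluorophenyl, although halogen and ring place change together in the first two steps. No evidence on the origin of these numbers is available.

Separating halogen from place would need 3-fluorophenyl or 4-bromophenyl. Also open, going by these compounds, is whether an amine or carboxylic acid on this ring would move the number beyond the scatter.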